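Swapping an indole for fluorophenyl on the amine nitrogen

A few compounds are considered here, and "the series" means these few. Any claim that something is new, unique, unknown or untested is made for them only; others in the source may bear on it.

In a functional assay on HCT-116 cells (Homo sapiens) for cytotoxicity, read by MTT assay, with a stated time of 48 h (on this read-out higher numbers stand for weaker inhibition and lower numbers for stronger inhibition), compound 3 `O=C(/C=C\Nc1ccc2[nH]ccc2c1)c1nc(-c2ccc(C(F)(F)F)cc2)n2ccccc12` gives 27100 nM, the higher of the two numbers recorded. Compound 2 `COc1ccc(-c2nc(C(=O)/C=C\Nc3ccc4[nH]ccc4c3)c3ccccn23)cc1` gives 17400 nM, and the step of a 1.6-fold higher number from compound 2 to compound 3 (0.19 log units; within the scatter) stays within the scatter. Compound 1 `O=C(/C=C\Nc1ccc(F)cc1)c1nc(-c2ccc(F)cc2)n2ccccc12` reaches only the limit of > 30000 nM in this assay. Compound 4 `O=C(/C=C\Nc1ccc(F)cc1)c1nc(-c2ccc(C(F)(F)F)cc2)n2ccccc12` differs from compound 3 by 4-fluorophenyl in place of 1H-indol-5-yl on an amine nitrogen. Among the measured compounds shown here, no measured step covers this change on its own. Compound 1 also carries the 4-fluorophenyl on its amine nitrogen but differs from compound 3 at a second place as well, so the limit of > 30000 nM in this assay, at which 1 of the 3 values shown sits, gives only a hint that this substituent does not help. Compound 4 is therefore expected at 40000 nM, between 15000 nM and 100000 nM. This expected step a 1.5-fold higher number from compound 3 to compound 4 (0.17 log units; within the scatter) would most likely leave compound 4 at the limit rather than as a number.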

Compound 4, half-maximal inhibitory concentration: > 30000 nM
Compound 4: a limit, no number; the forecaster's own chance of this, stated with the estimate: 65%; the middle value lies beyond the limit too.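

Among the compounds shown here, this is the first single change on the amine nitrogen, and 4-fluorophenyl in place of 1H-indol-5-yl gives an at least 1.1-fold higher number from compound 3 to compound 4 (0.04 log units; that floor lies within the scatter), so no real loss is established. The trifluoromethyl in place of fluoro step between compound 1 and compound 4 cannot be read. Both compounds with 4-fluorophenyl on the amine nitrogen, compound 1 and compound 4, give a limit and not a number: the limit of > 30000 nM in this assay, at which 2 of the 4 values shown sit.

From the compounds shown here alone, how far compound 4 lies past its limit stays open. So does how a phenyl carrying an amine or a carboxylic acid would read in place of 1H-indol-5-yl on the amine nitrogen.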